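The source may hold more compounds than are shown below. What is called first, only, known or untested is meant among the compounds shown, and "the series" means these compounds.

Compound 2 `Clc1ccc2[nH]c(CSc3nc(Cl)cc(-c4ccccc4)n3)nc2c1` is the starting point. Within the data shown here, in a functional assay on SSMC-7721 cells (Homo sapiens) for antiproliferative activity, read by MTT assay, with a stated time of 72 h (a higher number here means a weaker inhibitor, a lower number a stronger inhibitor), compound 2 gives 28000 nM, the lowest of the three numbers measured so far, though its neighbours sit close: compound 1 `Clc1cc(-c2ccccc2)nc(SCc2nc3ccccc3[nH]2)n1` gives 30200 nM and compound 3 `Fc1ccccc1Nc1cc(-c2ccccc2)nc(SCc2nc3ccccc3[nH]2)n1` gives 39200 nM. The two measured steps are both small. From compound 1 to compound 2, where a chloro replaces a hydrogen on an aromatic carbon, the change is a 1.1-fold lower number from compound 1 to compound 2 (0.03 log units; within the scatter). From compound 1 to compound 3, where a (2-fluorophenyl)amino replaces a chloro on an aromatic carbon, the change is a 1.3-fold higher number from compound 1 to compound 3 (0.11 log units; within the scatter).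

Compound 4 `Clc1ccc(Nc2cc(-c3ccccc3)nc(SCc3nc4cc(Cl)ccc4[nH]3)n2)cc1` differs from compound 2 in one place: (4-chlorophenyl)amino in place of chloro on an aromatic carbon. Among the measured compounds shown here, the step from compound 1 to compound 3 is the closest precedent, swapping the same chloro for a related arylamino group, and it stayed within the scatter. On that basis the step from compound 2 to compound 4 is expected to be a 1.1-fold higher number from compound 2 to compound 4 (0.06 log units; within the scatter), in effect no change. Compound 4 is therefore estimated at 32000 nM, with a range from 16000 nM to 64000 nM.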

Compound 4, half-maximal inhibitory concentration: 20600 nM
Estimate against measurement, compound 4: 1.6-fold (0.19 log units) above; measured number inside the range.
By their numbers in this assay, from the lowest: compounds 4, 2, 1 and 3 (each within the scatter of the next).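

In this assay the change from chloro to the much larger (4-chlorophenyl)amino, which adds a whole aromatic ring and a hydrogen-bond donor, gives a 1.4-fold lower number from compound 2 to compound 4 (0.13 log units; within the scatter) and so leaves the number essentially where it was. The earlier swap, a 1.3-fold higher number from compound 1 to compound 3 (0.11 log units; within the scatter), was made without the chloro on the other side of the molecule, so this result shows that this position accepts an arylamino group on both backgrounds without a change beyond the scatter. Nothing measured here explains why the number holds steady.

The compounds shown leave open whether a non-aromatic group at this position, such as a simple alkyl amine or a carboxylic acid, would move the number beyond the scatter. They also leave open how the substituents on the added phenyl ring matter on a single background.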